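A few compounds are considered here, and "the series" means these few. Any claim that something is new, unique, unknown or untested is made for them only; others in the source may bear on it.

Measured so far in a functional assay on T47D cells (Homo sapiens) for antiproliferative activity, with a stated time of 72 h; a higher number here means a weaker inhibitor, a lower number a stronger inhibitor:

compound 1 `C#CCSc1cnc2ccccc2c1[Se]CC#CCCl` — 0.4 ug/mL
compound 2 `OCC#CCSc1cnc2ccccc2c1SCC#CCCl` — 5.3 ug/mL

Compound 2 holds the highest number of the two measured in this assay; compound 1 sits at a lower number, and the gap between the two lies beyond the usual scatter. Among the measured compounds shown here, no single-point step between compound 1 and compound 2 is available, so the pair shows only that compound 2 is the weaker of the two.

The next compound, compound 3 `C#CCSc1cnc2ccccc2c1SCC#CCCl`, is to be measured in this assay. It differs from compound 2 in one place: hydrogen in place of hydroxymethyl on a triple-bonded carbon. The change is a loss of the hydroxymethyl from the end of the alkyne chain, leaving a propargyl group in place of the 4-hydroxybut-2-yn-1-yl group.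

For the measured compounds named here, no measured step of this kind exists, so the direction can only be guessed from the two values at hand. Compound 3 is expected to give 2 ug/mL, with a range from 0.6 ug/mL to 6 ug/mL. The step of a 2.7-fold lower number from compound 2 to compound 3 (0.42 log units; beyond the scatter) is thus estimated as a modest move to a lower number, of a size that may or may not exceed the scatter.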

Compound 3, concentration for 50% inhibition: 5.8 ug/mL
For compound 3 the middle estimate is 2.9-fold (0.46 log units) below the measured one, within the range that was stated.
By their numbers in this assay, from the lowest: compound 1; then compounds 2 and 3 (each within the scatter of the next).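

In this assay, hydrogen in place of hydroxymethyl on a triple-bonded carbon gives a 1.1-fold higher number from compound 2 to compound 3 (0.04 log units; within the scatter), so the 4-hydroxybut-2-yn-1-yl and propargyl groups cannot be told apart at this position in this pair. Among the compounds shown here, compound 3 also provides the first comparison that differs in one place on the aromatic carbon: the selenium-containing group of compound 1 and the sulfur-containing group of compound 3, each of 6 heavy atoms, are separated by a 15-fold higher number from compound 1 to compound 3 (1.16 log units; beyond the scatter), a large step that places the clear difference in this set at that aromatic carbon rather than at the end of the alkyne chain. No measurement at hand bears on the reason for either step.

Open, as far as these compounds go, is whether the flat result at the triple-bonded carbon extends beyond hydroxymethyl and hydrogen, for example to an amine, a carboxylic acid or a longer alkyl chain at the same place. Also open is whether the hydroxymethyl-to-hydrogen result and the large step between the selenium and sulfur groups hold when both changes occur in one compound, since the pairs shown cover each change only once.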